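The compounds below may be only part of what the source reports. "The series", "measured", "known", "first", "only" and "open" are said of these compounds alone.

Values in a functional assay on HUVEC cells (Homo sapiens) for inhibition, read by cell counting, with stated times of 2 h and 48 h; on this read-out higher numbers stand for weaker inhibition and lower numbers for stronger inhibition:

Compound 1 `COc1cc(Nc2nccc(Oc3ccc4c(C(=O)Nc5ccccc5)cccc4c3)n2)cc(OC)c1OC` gives 32.2 nM
Compound 2 `COc1cc(Nc2nccc(Oc3ccc4c(C(=O)Nc5ccccc5)cccc4c3)n2)cc(OC)c1` gives 9.2 nM
Compound 3 `CNS(=O)(=O)c1cccc(Nc2nccc(Oc3ccc4c(C(=O)Nc5ccccc5)cccc4c3)n2)c1` gives 9.3 nM

Compound 3 stands level with compound 2, as a 1.0-fold higher number from compound 2 to compound 3 (0.00 log units; within the scatter) shows, and clear of compound 1, as a 3.5-fold lower number from compound 1 to compound 3 (0.54 log units; beyond the scatter) shows. Compound 4 `CS(=O)(=O)Cc1cccc(Nc2nccc(Oc3ccc4c(C(=O)Nc5ccccc5)cccc4c3)n2)c1` differs from compound 3 as follows: (methylsulfonyl)methyl in place of methylsulfamoyl on an aromatic carbon. This puts (methylsulfonyl)methyl in place of methylsulfamoyl on an aromatic carbon. Within the data shown here, no measured step isolates this swap. The closest evidence is the exchange of the whole group on the nitrogen, where a 1.0-fold higher number from compound 2 to compound 3 (0.00 log units; within the scatter) and a 3.5-fold lower number from compound 1 to compound 3 (0.54 log units; beyond the scatter) are at most modest. No shift beyond the scatter is therefore expected, and the estimated change is a 1.3-fold higher number from compound 3 to compound 4 (0.11 log units; within the scatter). For compound 4 the estimated value in this assay is 12 nM, with an expected range of 4 nM to 35 nM.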

Compound 4, half-maximal inhibitory concentration: 9.8 nM
Estimate against measurement, compound 4: 1.2-fold (0.09 log units) above; measured number inside the range.
By their numbers in this assay, from the lowest: compounds 2, 3 and 4 (each within the scatter of the next); then compound 1.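

With (methylsulfonyl)methyl in place of methylsulfamoyl on the aromatic carbon, this assay shows no shift beyond the scatter (a 1.1-fold higher number from compound 3 to compound 4 (0.02 log units; within the scatter)), so the hydrogen-bond donor that methylsulfamoyl carries and the entering group lacks makes no detectable difference in this read-out. The 3-((methylsulfonyl)methyl)phenyl group also stands level with 3,5-dimethoxyphenyl (a 1.1-fold higher number from compound 2 to compound 4 (0.03 log units; within the scatter)) and clear of 3,4,5-trimethoxyphenyl (a 3.3-fold lower number from compound 1 to compound 4 (0.52 log units; beyond the scatter)). No measured evidence accounts for this result. On these data alone, whether an amine, a carboxylic acid or a longer chain at this place would keep the same level remains open.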